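The source may report more compounds than this note shows. Statements on the series, on what has been measured and on what is new or still open speak of the compounds shown alone.

Measured so far in a functional assay on MCF7 cells (Homo sapiens) for cytotoxicity, read by WST assay, with a stated time of 72 h; on this read-out lower numbers stand for stronger inhibition and higher numbers for weaker inhibition:
- Compound 1 `Cc1ccc(C2(c3ccc(O)cc3)C(=O)Nc3c2ccc(F)c3F)cc1`: 1.7 nM
- Compound 2 `CCCCCOc1ccc(C2(c3ccc(O)cc3)C(=O)Nc3c2ccc(F)c3F)cc1`: > 1000 nM, which is a limit of the assay and not a number
- Compound 3 `COc1ccc(C2(c3cccc(O)c3)C(=O)Nc3c2ccc(F)c3F)cc1`: 196 nM

Compound 1 holds the lowest of the two true numbers, and the nearest value is that of compound 3, at 196 nM. Compound 4 `CCCCCC1(c2ccc(O)cc2)C(=O)Nc2c1ccc(F)c2F` has not yet been measured. It carries pentyl in place of 4-methylphenyl on a saturated ring carbon.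

Going by the values given here, only one measured step bears on this change, and it lies at a different place on the molecule. There, pentyloxy replaces methyl on an aromatic carbon, and the result is large: an at least 580-fold higher number from compound 1 to compound 2 (2.76 log units; beyond the scatter). On these data alone, compound 2 stands at the limit of > 1000 nM in this assay, at which 1 of the 3 values shown sits, so the true size of that step stays open. Compound 1 therefore looks sensitive to change at this part of the molecule, and a large rise is expected here too. The expected step is a 240-fold higher number from compound 1 to compound 4 (2.37 log units; beyond the scatter). In this assay the estimate for compound 4 is 400 nM, with an expected range from 40 nM to 3000 nM.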

Compound 4, half-maximal inhibitory concentration: 96 nM
Compound 4: middle estimate off by 4.2-fold (0.62 log units), on the high side; measured number inside the range.
By their numbers in this assay, from the lowest: compound 1; then compound 4; then compound 3. At a limit, above all of these: compound 2.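

With compound 4, the saturated ring carbon carries no aromatic ring for the first time among the compounds shown, and swapping 4-methylphenyl for pentyl there has a large cost in this assay: a 56-fold higher number from compound 1 to compound 4 (1.75 log units; beyond the scatter). Going by these compounds alone, this is the first step away from compound 1 whose size can be read, and it shows that activity at this carbon is lowered but not lost, as compound 4 still gives a true number of 96 nM. The only earlier step from compound 1 ends at a limit of the assay in compound 2, so its size cannot be read: the limit of > 1000 nM in this assay, at which 1 of the 4 values shown sits.

Pentyl is the only group without a ring shown at this carbon, so the single step cannot separate the loss of the aromatic ring from the nature of the chain that replaces it. A cyclohexyl group would separate the two, and a shorter chain such as propyl would show how far chain length matters here.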